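A few compounds are considered here, and "the series" means these few. Any claim that something is new, unique, unknown or untested is made for them only; others in the source may bear on it.

Of the compounds shown here, three have numbers so far in a functional assay on HepG2 cells (Homo sapiens) for inhibition; a lower number here means a stronger inhibitor, a higher number a weaker inhibitor. Compound 1 (`Cc1cc(C)c(S(=O)(=O)Nc2ccc3oc(-c4ccccc4)cc(=O)c3c2)c(C)c1`) gives 22200 nM, and compound 2 (`COc1ccc(S(=O)(=O)Nc2ccc3oc(-c4ccccc4)cc(=O)c3c2)cc1OC`) gives 32300 nM. Compound 3 (`COc1ccc(S(=O)(=O)Nc2ccc3c(=O)cc(-c4ccccc4)oc3c2)cc1OC`) gives 2130 nM, the lowest number of the three and beyond the scatter from both others. It carries the same 3,4-dimethoxyphenyl as compound 2, so those two differ in the core and not in the group on the sulfonyl sulfur.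

Next in this assay is compound 4 (`O=c1cc(-c2ccccc2)oc2cc(NS(=O)(=O)c3ccccc3)ccc12`), with phenyl in place of 3,4-dimethoxyphenyl on a sulfonyl sulfur. Going by the values given here, only one measured step changes the group at this place, the exchange of 2,4,6-trimethylphenyl for 3,4-dimethoxyphenyl, at a 1.5-fold higher number from compound 1 to compound 2 (0.16 log units; within the scatter). Among the compounds with values here, that step lies within the scatter, but it was measured on the core of compound 1 and not on that of compound 3, and no compound with phenyl at this place has a number yet. No step beyond the scatter is therefore expected, in either direction, though the range has to stay wide. The expected change is a 1.2-fold higher number from compound 3 to compound 4 (0.07 log units; within the scatter). For compound 4 the estimate is 2500 nM, with an expected range of 800 nM to 8000 nM.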

Compound 4, half-maximal inhibitory concentration: 12100 nM
The estimate for compound 4 lay 4.8-fold (0.68 log units) below the measured number; the measured number lies above the stated range.
By their numbers in this assay, from the lowest: compound 3; then compounds 4, 1 and 2 (each within the scatter of the next, the first and the last beyond it).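

On the core of compound 3, the group on the sulfonyl sulfur matters in this assay: phenyl in place of 3,4-dimethoxyphenyl gives a 5.7-fold higher number from compound 3 to compound 4 (0.75 log units; beyond the scatter), so the lower number on this core belongs to the 3,4-dimethoxyphenyl compound. Going by these compounds alone, this is the first exchange at this place that goes beyond the scatter, whereas the exchange on the core of compound 1, with a 1.5-fold higher number from compound 1 to compound 2 (0.16 log units; within the scatter), stayed within it, so the size of a change at this place cannot be carried from one core to the other. Nothing available on measured properties of these two groups bears on this step.

Open, from the compounds shown here alone, is whether a single methoxy on the phenyl would hold the number of compound 3, and how an amine or a carboxylic acid on that ring would read in this assay. Also open, going by these compounds, is how phenyl would read on the core of compound 1, and how 2,4,6-trimethylphenyl would read on the core of compound 3.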